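Moving one fluorine on the benzoate of compound 2

The source may report more compounds than this note shows. Statements on the series, on what has been measured and on what is new or still open speak of the compounds shown alone.

Measured in a functional assay on MCF7 cells (Homo sapiens) for antiproliferative activity, read by MTT assay, with a stated time of 72 h; a higher number here means a weaker inhibitor, a lower number a stronger inhibitor:
- Compound 1 `CC1=CC[C@H]2[C@H](CC[C@]2(C)O)C(C)(C)[C@@H]1CC[C@H]1[C@]2(C)CC[C@H](OC(=O)c3ccc(F)cc3)C(C)(C)O[C@H]2CC[C@@]1(C)O`: 33500 nM
- Compound 2 `CC1=CC[C@H]2[C@H](CC[C@]2(C)O)C(C)(C)[C@@H]1CC[C@H]1[C@]2(C)CC[C@H](OC(=O)c3ccc(C(F)(F)F)cc3F)C(C)(C)O[C@H]2CC[C@@]1(C)O`: > 50000 nM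

Compound 2 reads > 50000 nM, which is a limit of the assay and not a number. Compound 3 `CC1=CC[C@H]2[C@H](CC[C@]2(C)O)C(C)(C)[C@@H]1CC[C@H]1[C@]2(C)CC[C@H](OC(=O)c3ccc(C(F)(F)F)c(F)c3)C(C)(C)O[C@H]2CC[C@@]1(C)O` keeps the shared core and differs from compound 2 in one place. The difference is 3-fluoro-4-(trifluoromethyl)phenyl in place of 2-fluoro-4-(trifluoromethyl)phenyl on a carbonyl carbon.

For the measured compounds named here, only one measured step bears on this, and it is an at least 1.4-fold higher number from compound 1 to compound 2 (0.17 log units; that floor lies within the scatter). Going by the values given here, that step is a floor that stays within the scatter, and no measured step shows the fluorine moving on its own. No step beyond the scatter is therefore expected in this assay, and no firm direction can be given. The expectation is anchored on compound 1 at 33500 nM. Compound 3 may also end at the limit. The expected step is an at least 1.1-fold lower number from compound 2 to compound 3 (0.07 log units; that floor lies within the scatter), an estimated figure set against a limit. Compound 3 is estimated at 42000 nM, with an expected range of 20000 nM to 80000 nM.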

Compound 3, half-maximal inhibitory concentration: > 50000 nM
Compound 3 gave a limit, no number; the forecaster's own chance of this, stated with the estimate: 45%; at least 1.1-fold (0.07 log units) between middle value and limit.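

In this assay compound 3 gives > 50000 nM, which is a limit of the assay and not a number, so 3-fluoro-4-(trifluoromethyl)phenyl on the carbonyl carbon reaches the same limit as the 2-fluoro-4-(trifluoromethyl)phenyl group of compound 2. Replacing 4-fluorophenyl with this group gives an at least 1.4-fold higher number from compound 1 to compound 3 (0.17 log units; that floor lies within the scatter), so this change does not establish a real loss of activity, and the shift of the fluorine leaves the reading at the limit rather than bringing out a number. The step between the two fluorine placements cannot be read, because both compounds give only a limit: the limit of > 50000 nM in this assay, at which 2 of the 3 values shown sit.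

The compounds shown leave open whether the placement of the fluorine has any effect on antiproliferative activity, as neither placement gives a number that could be compared. They also leave open how the benzoate would behave if an amine or a carboxylic acid stood in place of the trifluoromethyl group.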